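Amide nitrogen alkyl chain in the pyrazole carboxamide series

The source may hold more compounds than are shown below. What is called first, only, known or untested is meant among the compounds shown, and "the series" means these compounds.

Compound 1 `CCCCOc1cc(C(N)=O)nn1-c1ccccc1` gives 26.5% in a functional assay on the whole organism (strain Wistar) for inhibition, with Rattus norvegicus as the target, read by paw edema, with stated times of 30 min and 3 h, at a dose of 100 mg/kg by the oral route; a higher number here means more inhibition at the dose given (going by the name of the read-out), a lower number less inhibition. Going by the values given here, compound 2 `CCCCOc1cc(C(=O)NCC)nn1-c1ccccc1` gives 0% in this assay, the lower of the two numbers; the step of a number 26.5 percentage points lower from compound 1 to compound 2 (beyond the scatter) is the only measured step in the set. Compound 3 `CCCCOc1cc(C(=O)NCCC)nn1-c1ccccc1` differs from compound 2 by methyl in place of hydrogen on a saturated chain carbon, two bonds along the chain from an amide-type nitrogen. Among the compounds with values here, no measured step bears directly on this change, since the one measured step concerns the amide nitrogen itself rather than the chain beyond it. No step beyond the scatter is therefore expected from compound 2 to compound 3, so the estimate for compound 3 is 3%, range 0% to 15%, an expected step of a number 3 percentage points higher from compound 2 to compound 3 (within the scatter).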

Compound 3, a percentage reported as inhibition, in the whole organism at one dose (the size of the read-out at that dose, not a potency): 51.2%
Compound 3: middle estimate off by 48.2 percentage points, on the low side; measured number outside the range, above it.
By their numbers in this assay, from the lowest: compound 2; then compound 1; then compound 3.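

In this assay, the amide nitrogen substituent does not act through alkylation alone: methyl on a saturated chain carbon, two bonds along the chain from an amide-type nitrogen, gives a number 51.2 percentage points higher from compound 2 to compound 3 (beyond the scatter) and so reverses the loss seen with ethyl. Propyl in place of hydrogen on the amide nitrogen gives a number 24.7 percentage points higher from compound 1 to compound 3 (beyond the scatter), so substitution here is not uniformly unfavourable, and compound 2 goes against any simple trend with chain length. No measured evidence accounts for this reversal.

Going by these compounds, whether a longer chain such as butyl or pentyl keeps this level remains open. On these data alone, the effect of a branched isopropyl group or a cyclopropyl ring on the amide nitrogen is also open.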